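Hydroxy to carbamoyl: expected lipophilicity of compound 4

A few compounds are considered here, and "the series" means these few. Any claim that something is new, unique, unknown or untested is made for them only; others in the source may bear on it.

Compound 1, `C#CCNC(=O)C[C@H](NC(=O)c1ccc(C#Cc2ccccc2)cc1)C(=O)NO`, gives 3 in a physicochemical assay for lipophilicity; a higher number here means a more lipophilic compound, a lower number a more polar compound.
Compound 2, `O=C(N[C@@H](CO)C(=O)NO)c1ccc(C#Cc2ccccc2)cc1`, gives 2 in this assay.
Compound 3, `O=C(NC1(C(=O)NO)CCCCC1)c1ccc(C#Cc2ccccc2)cc1`, gives > 3 in this assay.

The value of compound 3 is a limit of the assay, not a number (the limit of > 3 in this assay, at which 1 of the 3 values shown sits). Of the two numbers, compound 2 stands lowest. For the measured compounds named here, the one measured step that bears on it is a number 1.00 log units lower from compound 1 to compound 2 (beyond the scatter). Compound 4, `NC(=O)C[C@H](NC(=O)c1ccc(C#Cc2ccccc2)cc1)C(=O)NO`, differs from compound 2 by carbamoyl in place of hydroxy on a saturated chain carbon, two bonds along the chain from an amide-type nitrogen and a carbonyl carbon. The carbamoyl that enters is only part of the propargylcarbamoyl removed in that measured step, so a step smaller than it is expected, with no clear direction beyond the scatter. Compound 4 is therefore estimated at 1.9, between 1.4 and 2.5, an expected change of a number 0.10 log units lower from compound 2 to compound 4 (within the scatter).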

Compound 4, distribution coefficient: 1
Beside the measured number, compound 4's estimate is 0.90 log units above it; measured number outside the range, below it.
By their numbers in this assay, from the lowest: compound 4; then compound 2; then compound 1.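

Putting carbamoyl in place of hydroxy on this saturated chain carbon gives a number 1.00 log units lower from compound 2 to compound 4 (beyond the scatter) in this assay even though the entering group has more heavy atoms. Taking propargyl off the amide-type nitrogen gives a number 2.00 log units lower from compound 1 to compound 4 (beyond the scatter) and is the largest numerical step among these compounds. Nothing measured here accounts for either step.

From the compounds shown here alone, whether an amine or a carboxylic acid on this carbon would give a number above or below that of compound 4 stays open. So does the effect of a longer chain carrying the carbamoyl.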